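The source may report more compounds than this note shows. Statements on the series, on what has been measured and on what is new or still open speak of the compounds shown alone.

Measured so far in a functional assay on PC-3 cells (Homo sapiens) for cytotoxicity; on this read-out lower numbers stand for stronger inhibition and higher numbers for weaker inhibition:

- compound 1 `O=C(CCCCCCC(=O)Nc1nc2ccccc2s1)NO`: 5.44 ug/mL
- compound 2 `Cc1ccc2nc(NC(=O)CCCCCCC(=O)NO)sc2c1`: 0.53 ug/mL
- compound 3 `O=C(CCCCCCC(=O)Nc1nc2ccc([N+](=O)[O-])cc2s1)NO`: 1.28 ug/mL

Of these three, compound 1 carries the highest number, so both of its measured neighbours are stronger in this assay. The next compound to be measured is compound 4 `O=C(CCCCC(=O)Nc1nc2ccccc2s1)NO`, which keeps the core of compound 1 and alters only the chain: hydroxycarbamoyl in place of 2-(hydroxycarbamoyl)ethyl on a saturated chain carbon, four bonds along the chain from a carbonyl carbon. In words, hydroxycarbamoyl stands in place of 2-(hydroxycarbamoyl)ethyl on a saturated chain carbon, four bonds along the chain from a carbonyl carbon.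

Going by the values given here, no measured step touches this chain. All of them are changes on an aromatic carbon: methyl in place of hydrogen gave a 10-fold lower number from compound 1 to compound 2 (1.01 log units; beyond the scatter), and nitro in place of hydrogen gave a 4.3-fold lower number from compound 1 to compound 3 (0.63 log units; beyond the scatter). These steps show only how far a single change has moved the numbers in this small set, not which way a shorter chain will move them. A higher number is therefore a tentative expectation, resting on the structural change alone, with a size near the modest step to compound 3, a 4.3-fold lower number from compound 1 to compound 3 (0.63 log units; beyond the scatter). The expected change is a 2.2-fold higher number from compound 1 to compound 4 (0.34 log units; beyond the scatter). The estimate for compound 4 is 12 ug/mL, with an expected range of 3.5 ug/mL to 40 ug/mL.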

Compound 4, half-maximal inhibitory concentration: 12.5 ug/mL
Beside the measured number, compound 4's estimate is 1.0-fold (0.02 log units) below it; low and high end bracket the measured number.
By their numbers in this assay, from the lowest: compound 2; then compound 3; then compound 1; then compound 4.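

Going by these compounds alone, compound 4 gives the first reading on the chain rather than on an aromatic carbon. In this assay, hydroxycarbamoyl in place of 2-(hydroxycarbamoyl)ethyl on a saturated chain carbon, four bonds along the chain from a carbonyl carbon, gave (a 2.3-fold higher number from compound 1 to compound 4 (0.36 log units; beyond the scatter)), so the number responds to this change in chain length, and it moves the opposite way to the two changes on an aromatic carbon, methyl (a 10-fold lower number from compound 1 to compound 2 (1.01 log units; beyond the scatter)) and nitro (a 4.3-fold lower number from compound 1 to compound 3 (0.63 log units; beyond the scatter)). Nothing available explains why the shorter chain carries the higher number.

With only these two chain lengths shown on the core of compound 1, it remains open whether a longer chain would lower the number further or whether the trend would reverse, and whether methyl or nitro on an aromatic carbon would lower the number on the shorter chain as they do on the longer one. Going by these compounds, it is also open how the number would respond if a carboxylic acid or an amine stood in place of the hydroxycarbamoyl at the end of the chain.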